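Moving a methyl group: 3-methylphenyl to 4-methylphenyl

The source may report more compounds than this note shows. Statements on the series, on what has been measured and on what is new or still open speak of the compounds shown alone.

Measured in a functional assay on Jurkat cells (Homo sapiens); a higher number here means a weaker inhibitor, a lower number a stronger inhibitor:
Compound 1 `C[C@H](NC(=O)C(=O)NCC1CCCCC1)C(=O)N[C@@H](CC(=O)O)C(=O)COc1c(F)c(F)cc(F)c1F`: 19 nM
Compound 2 `Cc1cccc(CNC(=O)C(=O)N[C@@H](C)C(=O)N[C@@H](CC(=O)O)C(=O)COc2c(F)c(F)cc(F)c2F)c1`: 127 nM

Of these two, compound 2 carries the higher number, which makes it the weaker inhibitor. The next molecule, compound 3 `Cc1ccc(CNC(=O)C(=O)N[C@@H](C)C(=O)N[C@@H](CC(=O)O)C(=O)COc2c(F)c(F)cc(F)c2F)cc1`, has not yet been measured. It differs from compound 2 in one group only: 4-methylphenyl in place of 3-methylphenyl on a saturated chain carbon bound to an amide-type nitrogen. The two have the same atoms, joined differently, with 4-methylphenyl in place of 3-methylphenyl on a saturated chain carbon bound to an amide-type nitrogen.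

Among the compounds with values here, only one measured step touches this place: a 6.7-fold higher number from compound 1 to compound 2 (0.83 log units; beyond the scatter). There, 3-methylphenyl replaced cyclohexyl, which is a different kind of exchange from the one at hand. Within the data shown here, no measured pair shows what happens when only the methyl group changes place, so the direction remains open. In this assay, the expected result is a 1.1-fold lower number from compound 2 to compound 3 (0.02 log units; within the scatter), a step not expected to go beyond the scatter. For compound 3 the estimated value is 120 nM, with an expected range from 50 nM to 300 nM.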

Compound 3, half-maximal inhibitory concentration: 50 nM
Beside the measured number, compound 3's estimate is 2.4-fold (0.38 log units) above it; low and high end bracket the measured number.
By their numbers in this assay, from the lowest: compound 1; then compound 3; then compound 2.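

In this assay, moving a single methyl group around the aromatic ring, with no atom gained or lost, gives a 2.5-fold lower number from compound 2 to compound 3 (0.40 log units; beyond the scatter), so this position responds to where the methyl group sits and not only to which atoms are present. The aromatic ring still does not match the saturated one: replacing cyclohexyl with 4-methylphenyl gives a 2.6-fold higher number from compound 1 to compound 3 (0.42 log units; beyond the scatter), a smaller rise than the one printed for 3-methylphenyl, and compound 1 remains the strongest inhibitor of the three. No supporting measurement is available to explain why the 4-methylphenyl group gives the lower number of the two isomers.

With only two methyl placements and one saturated ring, these compounds do not show whether the methyl group helps at all, which a plain phenyl group would test, or whether another group in the same place, such as 4-chlorophenyl or 4-methoxyphenyl, would follow compound 3. From the compounds shown here alone, it also remains open whether a saturated ring of another size, such as cyclopentyl, would keep the standing of compound 1.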